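Swapping chloro for methyl on the sulfonyl phenyl

The source may hold more compounds than are shown below. What is called first, only, known or untested is meant among the compounds shown, and "the series" means these compounds.

Compound 1 `O=C(NS(=O)(=O)c1ccccc1)n1ccc2cccnc21`: 19%
Compound 2 `O=C(NS(=O)(=O)c1ccc(Cl)cc1)n1ccc2cccnc21`: 33.5%

In a functional assay on MCF7 cells (Homo sapiens) for antiproliferative activity, read by MTT assay, with a stated time of 24 h, tested at 10 uM (on this read-out higher numbers stand for more inhibition at the one concentration tested (going by the name of the read-out) and lower numbers for less inhibition), compound 2 gives 33.5%, the higher of the two numbers, while compound 1 gives 19%. Within the data shown here, the single measured step, a number 14.5 percentage points higher from compound 1 to compound 2 (beyond the scatter), shows that adding chloro raised inhibition. Compound 3 `Cc1ccc(S(=O)(=O)NC(=O)n2ccc3cccnc32)cc1` differs from compound 2 in one place: methyl in place of chloro on an aromatic carbon. Among the measured compounds shown here, no measured step exchanges chloro for methyl, so that step bears only loosely here. A small fall, or none beyond the scatter, is expected, a number 5.5 percentage points lower from compound 2 to compound 3 (within the scatter). Compound 3 is therefore estimated at 28%, within 12% to 42%.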

Compound 3, a percentage reported as inhibition, at one concentration (the size of the read-out at that concentration, not a potency): 20.3%
Compound 3: the middle estimate sits 7.7 percentage points above what was measured; measured number inside the range.
By their numbers in this assay, from the lowest: compounds 1 and 3 (each within the scatter of the next); then compound 2.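

At this ring position, the gain seen with chloro does not extend to every small group: in this assay, replacing it with methyl gives a number 13.2 percentage points lower from compound 2 to compound 3 (beyond the scatter), while methyl compared with hydrogen gives a number 1.3 percentage points higher from compound 1 to compound 3 (within the scatter). Chloro and methyl each bring one heavy atom, so that count alone does not set the result among these compounds. Nothing measured here explains the difference. Going by these compounds, whether bromo, fluoro, methoxy or an amine at this position would match chloro remains open.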